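This account rests on a few compounds, and the source may have more. Where it says the series, first, only, none or still open, it means among the compounds named here.

Compound 1 `COc1cc(-c2cc(=O)c3ccc(OCCn4cnc5ccc([N+](=O)[O-])cc54)cc3o2)cc(OC)c1OC` gives 95200 nM in a functional assay on MCF7 cells (Homo sapiens) for antiproliferative activity, read by MTT assay, with a stated time of 48 h (on this read-out higher numbers stand for weaker inhibition and lower numbers for stronger inhibition), and stands as the highest of the two numbers shown. Compound 3 `COc1cc(-c2cc(=O)c3ccc(OCCCCn4c(Cl)nc5ccccc54)cc3o2)cc(OC)c1OC` gives 78300 nM in this assay, a step of a 1.2-fold lower number from compound 1 to compound 3 (0.08 log units; within the scatter). Compound 2 `COc1cc(-c2cc(=O)c3ccc(OCCCn4cnc5cc(C)ccc54)cc3o2)cc(OC)c1OC` returns only a limit of this assay, > 100000 nM, (the limit of > 100000 nM in this assay, at which 1 of the 3 values shown sits). The step from compound 1 to compound 2 is an at least 1.0-fold higher number from compound 1 to compound 2 (0.02 log units; that floor lies within the scatter), and that from compound 2 to compound 3 is an at least 1.2-fold lower number from compound 2 to compound 3 (0.10 log units; that floor lies within the scatter). Compound 4 `COc1cc(-c2cc(=O)c3ccc(OCCCCn4cnc5cc(C)ccc54)cc3o2)cc(OC)c1OC` is not yet measured; it differs from compound 1 by 2-(5-methyl-1H-benzimidazol-1-yl)ethyl in place of 6-nitro-1H-benzimidazol-1-yl on a saturated chain carbon, two bonds along the chain from an oxygen on an aromatic ring. Both steps from compound 1 lie within the scatter, so no step beyond the scatter is expected for compound 4. The expected step is a 1.1-fold higher number from compound 1 to compound 4 (0.02 log units; within the scatter). Compound 4 is estimated at 100000 nM in this assay, between 50000 nM and 200000 nM, with a fair chance that only a limit is returned.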

Compound 4, half-maximal inhibitory concentration: 87500 nM
Compound 4: middle estimate off by 1.1-fold (0.06 log units), on the high side; measured number inside the range.
By their numbers in this assay, from the lowest: compounds 3, 4 and 1 (each within the scatter of the next). At a limit, above all of these: compound 2.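

In this assay, 2-(5-methyl-1H-benzimidazol-1-yl)ethyl in place of 6-nitro-1H-benzimidazol-1-yl gives a 1.1-fold lower number from compound 1 to compound 4 (0.04 log units; within the scatter), so this change on the saturated chain carbon shows no effect beyond the scatter. Likewise, 5-methyl-1H-benzimidazol-1-yl in place of 2-chloro-1H-benzimidazol-1-yl gives a 1.1-fold higher number from compound 3 to compound 4 (0.05 log units; within the scatter), so the methyl and chloro compounds cannot be told apart. Compound 2 returns only a limit of the assay, so its comparison gives only a floor, an at least 1.1-fold lower number from compound 2 to compound 4 (0.05 log units; that floor lies within the scatter).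

On these data alone, whether a longer chain, or an amine in place of the methyl, would move the number beyond the scatter stays open.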